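Methoxy to isobutoxy on the tripropyl enol core

The compounds below may be only part of what the source reports. "The series", "measured", "known", "first", "only" and "open" are said of these compounds alone.

Compound 1 `CCCC1=C(OC)C(CCC)(CCC)C(=O)/C(=C(O)\C=C\c2ccccc2)C1=O` carries a methoxy group on the shared core and gives "not determined" (no result reported) in a functional assay on MCF7 cells (Homo sapiens) for antiproliferative activity, read by sulforhodamine B assay, with a stated time of 3 days; on this read-out lower numbers stand for an effect already at smaller amounts and higher numbers for an effect only at larger amounts of compound; the series gives no single number for it, so it cannot be placed on the scale. Two relatives have been measured. Compound 2 `CCCC1=C(OC)C(CCC)(CCC)C(=O)/C(=C(O)\C=C\c2ccc(I)cc2)C1=O` differs from compound 1 by an iodine on the styryl ring; in this assay compound 2 gives 1.8 uM. Compound 3 `COC1=C(CC(C)C)C(=O)/C(=C(O)/C=C/c2ccccc2)C(=O)C1(CC(C)C)CC(C)C`, an analogue with isobutyl chains in place of the propyl chains, gives 3.7 uM in this assay. These two values lie within the usual scatter of each other, so they describe one level of activity for this family rather than an order.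

Compound 4 `CCCC1=C(OCC(C)C)C(CCC)(CCC)C(=O)/C(=C(O)\C=C\c2ccccc2)C1=O` is the next member: isopropyl in place of hydrogen on a saturated chain carbon bound to an oxygen on an unsaturated carbon. Among the compounds with values here, no measured pair shows this step, and compound 1 itself has no value, so the size of the step cannot be read from the data. In this assay a step of no more than the usual scatter is expected in either direction, with the level set by the two measured relatives rather than by compound 1.

For compound 4 a value of 3 uM is expected in this assay, with the range 1 uM to 10 uM.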

Compound 4, concentration for half-maximal effect: 4.4 uM
The estimate for compound 4 lay 1.5-fold (0.17 log units) below the measured number; the measured number falls inside the stated range.
By their numbers in this assay, from the lowest: compound 2; then compounds 3 and 4 (each within the scatter of the next).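

In this assay compound 1 gives "not determined" (no result reported) and compound 4 gives 4.4 uM, so no step can be read from this pair. The compounds shown leave open what the change from methoxy to isobutoxy does to activity on the shared core. No data shown here bear on the level of compound 4.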